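The source may report more compounds than this note shows. Statements on the series, on what has been measured and on what is new or still open speak of the compounds shown alone.

Within the data shown here, compound 1 `CN(C)CCn1cnnc1-c1cc(Oc2ccc(NC(=O)N/N=C/c3cccc(Br)c3)cc2F)ccn1` stands at the lowest of the two numbers so far: in a functional assay on NCI-H460 cells (Homo sapiens) for cytotoxicity, read by MTT assay, with a stated time of 72 h (a lower number here means a stronger inhibitor, a higher number a weaker inhibitor), compound 1 gives 520 nM, while compound 2 `CN(C)CCn1cnnc1-c1cc(Oc2ccc(NC(=O)N/N=C/c3cc(Br)c(O)c(Br)c3)cc2F)ccn1` gives 3760 nM. Among the measured compounds shown here, the one measured step, a 7.2-fold higher number from compound 1 to compound 2 (0.86 log units; beyond the scatter), changed the same aryl group that changes now. Compound 3 `CN(C)CCn1cnnc1-c1cc(Oc2ccc(NC(=O)N/N=C/c3c[nH]c4ccccc34)cc2F)ccn1` differs from compound 1 by 1H-indol-3-yl in place of 3-bromophenyl on a carbon with a double bond to nitrogen. That earlier step shows a swap at this aryl group can weaken the inhibitor modestly, yet the entering group is a different one, and the direction stays uncertain. The expected step is a 1.7-fold higher number from compound 1 to compound 3 (0.24 log units; within the scatter). Compound 3 is therefore estimated at 900 nM, within a range from 250 nM to 3500 nM.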

Compound 3, half-maximal inhibitory concentration: 1630 nM
Beside the measured number, compound 3's estimate is 1.8-fold (0.26 log units) below it; the measured number falls inside the stated range.
By their numbers in this assay, from the lowest: compound 1; then compound 3; then compound 2.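

In this assay, the larger two-ring 1H-indol-3-yl still leaves the compound active, and it falls between the two earlier aryl groups. Replacing 3-bromophenyl with it gives a 3.1-fold higher number from compound 1 to compound 3 (0.50 log units; beyond the scatter), while replacing 3,5-dibromo-4-hydroxyphenyl with it gives a 2.3-fold lower number from compound 2 to compound 3 (0.36 log units; beyond the scatter). Nothing measured here explains this order. Still open, from the compounds shown here alone, is what a plain phenyl would give, which could show how much the bromine contributes. A phenyl carrying an amine or a carboxylic acid would test this position with quite different groups.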